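Halogen Swap on a Urea Already at the Assay Limit

The source may hold more compounds than are shown below. What is called first, only, known or untested is meant among the compounds shown, and "the series" means these compounds.

The two measured compounds share one core and differ only in the phenyl ring of the urea. Compound 1 `O=C(Nc1ccc(Nc2ncnc3c2OCCN3)cc1)Nc1ccc(Cl)c(C(F)(F)F)c1` carries a chloro and a trifluoromethyl on that ring; in an assay on isolated protein for inhibition of proto-oncogene tyrosine-protein kinase receptor Ret variant V804L (Homo sapiens), read by 33P incorporation, with stated times of 15 min and 40 min (a lower number here means a stronger inhibitor, a higher number a weaker inhibitor), compound 1 gives 285 nM. Compound 2 `O=C(Nc1ccc(Cl)cc1)Nc1ccc(Nc2ncnc3c2OCCN3)cc1` keeps only the chloro. In this assay compound 2 gives > 10000 nM, which is a limit of the assay and not a number. Among the compounds with values here, the single measured step, an at least 35-fold higher number from compound 1 to compound 2 (1.54 log units; beyond the scatter), is the only movement on record, and it places compound 2 at the limit of > 10000 nM in this assay, at which 1 of the 2 values shown sits.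

Compound 3 `O=C(Nc1ccc(Br)cc1)Nc1ccc(Nc2ncnc3c2OCCN3)cc1` is the next variant: bromo in place of chloro on an aromatic carbon. Within the data shown here, no measured step concerns a halogen exchange of this kind; the one step on record removes a trifluoromethyl, and it tells nothing about chloro against bromo. He therefore expects the step from compound 2 to compound 3 in this assay to be a step that the limit leaves unreadable from compound 2 to compound 3, that is, no movement beyond the scatter. He estimates that compound 3 gives about 15000 nM, within a range from 4000 nM to 50000 nM, and expects the assay most likely to report a limit again.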

Compound 3, half-maximal inhibitory concentration: > 10000 nM
Compound 3 was reported as a limit; the forecaster's own chance of this, stated with the estimate: 80%; the middle value lies beyond the limit too.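

In this assay compound 3 gives > 10000 nM, which is a limit of the assay and not a number. Within the data shown here, compound 2 also ends at a limit, so no step between compound 2 and compound 3 can be read: the limit of > 10000 nM in this assay, at which 2 of the 3 values shown sit. The compounds shown leave open whether bromo in place of chloro changes inhibition at all.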